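The source may hold more compounds than are shown below. What is called first, only, known or untested is meant among the compounds shown, and "the series" means these compounds.

Measured so far:
- Compound 1, `COc1cc2nc(N3CCN(C(=O)c4cccc5ccccc45)CC3)nc(N)c2cc1OC`: 59000 nM
- Compound 2, `COc1ccc(S(=O)(=O)N2CCN(c3nc(N)c4cc(OC)c(OC)cc4n3)CC2)cc1`: 39000 nM

Both compounds share a core and differ in the group attached to the ring nitrogen of that core. In a functional assay on PC-3 cells (Homo sapiens) for inhibition (on this read-out higher numbers stand for weaker inhibition and lower numbers for stronger inhibition), compound 1 gives 59000 nM, and in this assay compound 2 gives 39000 nM. Compound 2 has the lowest of the two numbers, but its nearest neighbour, compound 1, lies within the usual scatter of it, so the two cannot be told apart on these data.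

Compound 3, `COc1cc2nc(N3CCN(S(=O)(=O)c4cc(C(=O)O)c(Cl)cc4Cl)CC3)nc(N)c2cc1OC`, has not yet been measured. It differs from compound 2 in one place: 5-carboxy-2,4-dichlorophenyl in place of 4-methoxyphenyl on a sulfonyl sulfur. Among the measured compounds shown here, no step between two measured compounds resembles this change, so there is no direct guide to its size.

For the measured compounds named here, with only two measured compounds, both giving weak inhibition in this assay, the expectation for compound 3 is a number close to that of compound 2, with a step from a 1.2-fold higher number from compound 2 to compound 3 (0.06 log units; within the scatter) that is expected to stay within the scatter. Compound 3 is therefore estimated at 45000 nM, with a range from 12000 nM to 160000 nM.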

Compound 3, half-maximal inhibitory concentration: 52000 nM
Estimate against measurement, compound 3: 1.2-fold (0.06 log units) below; the range from low to high includes it.
By their numbers in this assay, from the lowest: compounds 2, 3 and 1 (each within the scatter of the next).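

In this assay, among the compounds shown here, putting 5-carboxy-2,4-dichlorophenyl in place of 4-methoxyphenyl on a sulfonyl sulfur gives a 1.3-fold higher number from compound 2 to compound 3 (0.12 log units; within the scatter) and is the first step that can be read between two measured compounds differing in one place. At this position, then, a group with two chlorine atoms and a carboxy group gives a number that cannot be told apart from that of the group with a methoxy substituent, even though the two groups share only the six-membered aromatic ring of carbon. The two compounds remain equally weak within the limits of this read-out, and nothing measured here accounts for the lack of a clear difference.

On these data alone, it remains open whether a 4-aminophenyl group or a longer alkyl chain on the sulfonyl sulfur would give a step beyond the scatter, and whether any group there would give much stronger inhibition. The carboxy group and the chlorine atoms enter together, so a phenyl group carrying only the carboxylic acid, or only the two chlorine atoms, would be needed to read each one separately.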